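The source may report more compounds than this note shows. Statements on the series, on what has been measured and on what is new or still open speak of the compounds shown alone.

Measured compounds in a functional assay on the whole organism (strain Wistar) for inhibition, with Rattus norvegicus as the target, read by paw edema, with a stated time of 4 h, at a dose of 10 mg/kg by the intraperitoneal route; on this read-out higher numbers stand for more inhibition at the one dose given (going by the name of the read-out) and lower numbers for less inhibition:
- compound 1 `O=C(N/N=C/c1ccccc1)c1cccnc1Nc1cccc(C(F)(F)F)c1` gives 31%
- compound 2 `O=C(N/N=C/c1ccc(Cl)cc1)c1cccnc1Nc1cccc(C(F)(F)F)c1` gives 43.7%
- compound 3 `CNc1ncccc1C(=O)N/N=C/c1ccccc1` gives 14.8%

For the measured compounds named here, the one counted step among them is a number 12.7 percentage points higher from compound 1 to compound 2 (beyond the scatter), made by the change (chloro in place of hydrogen on an aromatic carbon). Compound 3 carries a different core; the difference between its core and that of compound 1 is not broken down here, and its value stands beyond the scatter under those of compound 1 and compound 2.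

Compound 4 `CNc1ncccc1C(=O)N/N=C/c1cccc(Cl)c1` is to be measured in this assay. It differs from compound 3 by chloro in place of hydrogen on an aromatic carbon. This is the same kind of change as that from compound 1 to compound 2, though not the same: the chloro enters para to a large group in compound 2 and meta to a large group in compound 4.

For compound 4 a step of a number 12.2 percentage points higher from compound 3 to compound 4 (beyond the scatter) is expected, because the same kind of change gave a number 12.7 percentage points higher from compound 1 to compound 2 (beyond the scatter). Compound 4 is thus estimated at 27%, with a range from 15% to 40%.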

Compound 4, a percentage reported as inhibition, in the whole organism at one dose (the size of the read-out at that dose, not a potency): 40.4%
Compound 4: middle estimate off by 13.4 percentage points, on the low side; measured number outside the range, above it.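

In this assay, chloro in place of hydrogen on an aromatic carbon goes with a higher number on both cores, and on the core of compound 3 the change gives a number 25.6 percentage points higher from compound 3 to compound 4 (beyond the scatter). The two steps cannot be told apart: the same change on two cores in this assay, a number 12.7 percentage points higher (beyond the scatter) from compound 1 to compound 2 and a number 25.6 percentage points higher (beyond the scatter) from compound 3 to compound 4, 12.9 percentage points apart, within the scatter of two such steps. The direction of the change therefore carries across these two cores, but two pairs do not fix a step size, and with chloro placed differently in compound 2 and compound 4, the role of its place cannot be separated from that of the core.

Open, going by these compounds, is whether chloro meta to a large group on the core of compound 1 gives a similar step. Also open, on these data alone, is whether fluoro, methoxy or an amine at that place follows chloro.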